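Cytotoxicity on Vero cells: from compound 2 to compound 3

The source may hold more compounds than are shown below. What is called first, only, known or untested is meant among the compounds shown, and "the series" means these compounds.

In an ADME assay on Vero cells (Chlorocebus sabaeus) for cytotoxicity, read by WST assay (a lower number here means that less compound is tolerated, a higher number that more compound is tolerated), compound 1 `O=c1[nH]c(Nc2cc(Cl)cc(Cl)c2)nc2cc(C(F)(F)F)ccc12` gives 7100 nM. Compound 2 `O=c1[nH]c(Nc2cc(Cl)cc(Cl)c2)nc2cc([N+](=O)[O-])ccc12` reaches only a limit of this assay, > 25000 nM. The step of an at least 3.5-fold higher number from compound 1 to compound 2 (0.54 log units; beyond the scatter) is thus known only as a floor, since compound 2 sits at the limit of > 25000 nM in this assay, at which 1 of the 2 values shown sits. Compound 3 `O=c1[nH]c(Nc2cc(Cl)cc(Cl)c2)nc2cc(O)ccc12` differs from compound 2 by hydroxy in place of nitro on an aromatic carbon. No measured step covers this change; the one step shown, an at least 3.5-fold higher number from compound 1 to compound 2 (0.54 log units; beyond the scatter), concerns the group that now leaves. The expected step of an at least 1.2-fold lower number from compound 2 to compound 3 (0.09 log units; that floor lies within the scatter) is therefore set close to no change, with the range open downward. For compound 3 the estimate is 20000 nM, between 6000 nM and 60000 nM.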

Compound 3, half-maximal cytotoxic concentration: > 25000 nM
Compound 3 ended at the assay's limit (the forecaster's own chance of this, stated with the estimate: 40%); at least 1.2-fold (0.09 log units) between middle value and limit.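

Hydroxy in place of trifluoromethyl on this aromatic carbon gives an at least 3.5-fold higher number from compound 1 to compound 3 (0.54 log units; beyond the scatter) in this assay. Nitro is therefore no longer the only group shown to give a higher number than trifluoromethyl here, although the two groups differ in heavy atoms and hydrogen-bond donors. The step between compound 2 and compound 3 cannot be read, as both stand at a limit of the assay: the limit of > 25000 nM in this assay, at which 2 of the 3 values shown sit.

Any order between compound 2 and compound 3 remains open. Also open, going by these compounds, is whether an amine or a carboxylic acid on this carbon would reach the same limit or fall to a measurable number, as compound 1 does.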